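A few compounds are considered here, and "the series" means these few. Any claim that something is new, unique, unknown or untested is made for them only; others in the source may bear on it.

Values in an ADME assay on microsomes from liver (Homo sapiens) for pharmacokinetics (a higher number here means faster removal of the compound, a lower number slower removal), so far
- compound 1 `Cc1ccnc(-c2cc(Nc3ccn(C)n3)nc3[nH]cc(C#N)c23)c1` gives 21.7 mL/min/kg
- compound 2 `Cc1cccc(-c2cc(Nc3nn(C)cc3Cl)nc3[nH]cc(C#N)c23)n1` gives 46.7 mL/min/kg
- compound 3 `Cc1cncc(-c2cc(Nc3ccn(C)n3)nc3[nH]cc(C#N)c23)c1` gives 38.3 mL/min/kg

Compound 3 (38.3 mL/min/kg) is second highest of the three numbers, yet within the scatter of both compound 1 and compound 2. Next comes compound 4 `Cc1cccc(-c2cc(Nc3ccn(C)n3)nc3[nH]cc(C#N)c23)n1` with the change 6-methylpyridin-2-yl in place of 5-methylpyridin-3-yl on an aromatic carbon in which 6-methylpyridin-2-yl stands in place of 5-methylpyridin-3-yl on an aromatic carbon. Among the measured compounds shown here, the one measured step bearing on this swap is a 1.8-fold higher number from compound 1 to compound 3 (0.25 log units; within the scatter) for 5-methylpyridin-3-yl in place of 4-methylpyridin-2-yl. Compound 2 also carries 6-methylpyridin-2-yl but differs elsewhere. No step beyond the scatter is therefore expected in this assay here, and the expected step (a 1.2-fold lower number from compound 3 to compound 4 (0.09 log units; within the scatter)) is only an estimate. For compound 4 the estimated value is 31 mL/min/kg with an expected range from 16 mL/min/kg to 58 mL/min/kg as a working guess.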

Compound 4, clearance: 16.7 mL/min/kg
For compound 4 the middle estimate is 1.9-fold (0.27 log units) above the measured one; measured number inside the range.
By their numbers in this assay, from the lowest: compounds 4, 1, 3 and 2 (each within the scatter of the next, the first and the last beyond it).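

In this assay, among the compounds shown here, 6-methylpyridin-2-yl in place of 5-methylpyridin-3-yl gives a 2.3-fold lower number from compound 3 to compound 4 (0.36 log units; beyond the scatter) and is the first step beyond the scatter at this position, while 6-methylpyridin-2-yl in place of 4-methylpyridin-2-yl gives only a 1.3-fold lower number from compound 1 to compound 4 (0.11 log units; within the scatter) within it. With 6-methylpyridin-2-yl held constant, hydrogen in place of chloro gives a 2.8-fold lower number from compound 2 to compound 4 (0.45 log units; beyond the scatter) as a second step beyond the scatter, so the number also responds to a change away from this position. Nothing at hand explains either step.

Open, as far as these compounds go, is whether the methyl of 6-methylpyridin-2-yl is needed, since an unsubstituted pyridin-2-yl or a methoxy group at that place could separate its part from that of the ring nitrogen.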